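Esters of a shared core: from compound 2 to compound 3

The compounds below may be only part of what the source reports. "The series", "measured", "known", "first", "only" and "open" are said of these compounds alone.

Measured in a functional assay on HeLa cells (Homo sapiens) for cytotoxicity, read by MTT assay; on this read-out lower numbers stand for stronger inhibition and higher numbers for weaker inhibition:
- compound 1 (`CCC(C)(O)CC(=O)O[C@H](CC=C(C)C)C1=CC(=O)c2c(O)ccc(O)c2C1=O`) (25200 nM)
- compound 2 (`CCC(O)(CC)CC(=O)O[C@H](CC=C(C)C)C1=CC(=O)c2c(O)ccc(O)c2C1=O`) (52000 nM)

Not yet measured: compound 3 (`CC(C)=CC[C@@H](OC(=O)c1ccoc1)C1=CC(=O)c2c(O)ccc(O)c2C1=O`).

Of the two measured numbers, compound 2 has the higher (52000 nM). The next structure, compound 3, exchanges the ester side group (furan-3-yl in place of 2-ethyl-2-hydroxybutyl on a carbonyl carbon): furan-3-yl in place of 2-ethyl-2-hydroxybutyl on a carbonyl carbon. Among the measured compounds shown here, only one measured step bears on this (a 2.1-fold higher number from compound 1 to compound 2 (0.31 log units; beyond the scatter)). It was modest and came with methyl in place of hydrogen on the saturated chain. The present exchange is far larger than that step, so the guidance is weak. Since compound 3 carries the smaller group, a modest move to a lower number in this assay is expected (estimated as a 2.4-fold lower number from compound 2 to compound 3 (0.37 log units; beyond the scatter)). The estimate for compound 3 is 22000 nM (expected range 7000 nM to 65000 nM).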

Compound 3, half-maximal inhibitory concentration: > 100000 nM
Compound 3: no number, only a limit; the forecaster's own chance of this, stated with the estimate: 10%; at least 4.5-fold (0.65 log units) between middle value and limit.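

In this assay, the ester side group on the carbonyl carbon proves able to move the read-out further than the earlier methyl step did, and the exchange of the open chain for furan-3-yl goes towards weaker inhibition. Compound 3 gives no number, only a limit of the assay: the limit of > 100000 nM in this assay, at which 1 of the 3 values shown sits.

Read against the two chains, the exchange gives an at least 1.9-fold higher number from compound 2 to compound 3 (0.28 log units; that floor lies within the scatter) and an at least 3.9-fold higher number from compound 1 to compound 3 (0.59 log units; beyond the scatter), so only the comparison with the 2-hydroxy-2-methylbutyl ester is sure to lie beyond the scatter.

On these data alone, the true size of both steps stays open. The compounds shown also leave open whether the change follows the loss of the hydroxyl or the arrival of the ring, and how a plain butyl chain or a phenyl ring would read on this carbonyl carbon.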